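Removal of one chloro from the core: compound 2 to compound 3

The source may report more compounds than this note shows. Statements on the series, on what has been measured and on what is new or still open speak of the compounds shown alone.

Measured so far:
compound 1 `ClCc1ccc(Cn2cnc3c(Cl)ncnc32)cc1` — 4670 nM
compound 2 `ClCc1ccccc1Cn1cnc2c(Cl)nc(Cl)nc21` — 2880 nM

In a functional assay on TK-10 cells (Homo sapiens) for cytotoxicity, read by sulforhodamine B assay, with a stated time of 48 h (a lower number here means a stronger inhibitor of growth, a higher number a weaker inhibitor of growth), compound 2 gives 2880 nM, the lowest of the two numbers in hand. Compound 1 gives 4670 nM in this assay, and the gap between compound 2 and compound 1 lies within the scatter, so no order between the two can be read from these numbers. The two also differ in more than one place, so the comparison carries no single structural lesson.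

The next compound, compound 3 `ClCc1ccccc1Cn1cnc2c(Cl)ncnc21`, differs from compound 2 in one place: hydrogen in place of chloro on an aromatic carbon, on the shared core, at the carbon between two ring nitrogen atoms, meta to a chloro group and meta and para to the fused ring. Among the measured compounds shown here, no measured pair shows this change, so its size in this assay is unknown. Given that compound 1, which carries the same single-chloro core, gives 4670 nM, the expected step for this assay from compound 2 to compound 3 is a 1.5-fold higher number from compound 2 to compound 3 (0.16 log units; within the scatter), a small rise that may well sit within the scatter. Compound 3 is therefore expected at 4200 nM, with a range from 1500 nM to 12000 nM.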

Compound 3, concentration for total growth inhibition: 46800 nM
Beside the measured number, compound 3's estimate is 11-fold (1.05 log units) below it; the measured number lies above the stated range.
By their numbers in this assay, from the lowest: compounds 2 and 1 (each within the scatter of the next); then compound 3.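

Hydrogen in place of chloro on the aromatic carbon between two ring nitrogen atoms gives a 16-fold higher number from compound 2 to compound 3 (1.21 log units; beyond the scatter) in this assay and is the first readable single-place step in the series, so this position is not a neutral one for growth inhibition, even though the change removes only one heavy atom. The single-chloro core does not fix the number on its own: compound 1, with the same core and the chloromethyl group placed differently, gives 4670 nM while compound 3 gives 46800 nM in this assay, so the size of this step may hold only for the arrangement in compound 2 and compound 3. No measurement offers an explanation for the size of the step.

One pair cannot show whether the rise follows from the loss of chloro itself or would appear with any replacement at this carbon, and an amine, a methoxy group or a fluoro at the same carbon would test that. As far as these compounds go, whether the same change on the core of compound 1 gives a step of similar size also stays open.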